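The compounds below may be only part of what the source reports. "The series", "measured", "known", "first", "only" and "open" are said of these compounds alone.

Measured set in an assay on isolated protein for inhibition of calcium/calmodulin-dependent protein kinase type IV (Homo sapiens), read by HTRF, tested at 10 uM; on this read-out higher numbers stand for more inhibition at the one concentration tested (going by the name of the read-out) and lower numbers for less inhibition:

compound 1, `COC[C@@H]1CCCN1C(=O)C1CCCN1c1cc(Nc2cccc(Br)c2)ncn1` — 0%
compound 2, `Cc1cccc(Oc2ccnc(N3CCN(C(=O)c4c(C)noc4C)CC3)n2)c1` — 0%
compound 3, `Clc1ccc2sc(CN3CCN(c4ncnc5c4CN(Cc4ccccc4)CC5)CC3)cc2c1` — 0%

All three compounds return no measurable inhibition in this assay. For the measured compounds named here, compound 2 stands level with compound 1 and with compound 3 at the digits recorded; the gaps to both lie within the scatter, so no order among the three can be drawn, and no step between measured pairs is available to calibrate a change.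

The next compound, compound 4, `CC(=O)CCCCC(=O)N1CCN(c2nccc(Oc3cccc(C)c3)n2)CC1`, keeps the whole of compound 2 apart from one group on the carbonyl carbon whose other neighbour is the amide-type nitrogen in a ring:

4-acetylbutyl in place of 3,5-dimethyl-1,2-oxazol-4-yl on a carbonyl carbon

Going by the values given here, with compound 2 showing 0% in this assay and no measured step to build on, the expectation is for no change beyond the scatter, so the step from compound 2 to compound 4 is expected to be close to nothing, a number 2 percentage points higher from compound 2 to compound 4 (within the scatter). In this assay compound 4 is therefore estimated at 2%, with a range from -8% to 12%.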

Compound 4, a percentage reported as inhibition, at one concentration (the size of the read-out at that concentration, not a potency): 0%
Compound 4: middle estimate off by 2 percentage points, on the high side; the range from low to high includes it.
By their numbers in this assay, from the lowest: compounds 1, 2, 3 and 4 (each within the scatter of the next).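

In this assay, the carbonyl carbon now has a measured step, no change at the digits printed from compound 2 to compound 4 (within the scatter), on replacing 3,5-dimethyl-1,2-oxazol-4-yl with 4-acetylbutyl. At this position, an aromatic ring with hetero atoms and an open chain ending in a ketone therefore give the same reading on the shared core, but with compound 2 and compound 4 both at zero, the step cannot show whether this group would matter in a compound with measurable inhibition. Nothing available explains the result.

From the compounds shown here alone, it remains open whether an amine, a carboxylic acid or a longer chain on this carbonyl carbon would give any measurable inhibition. Also open, going by these compounds, is whether replacing the 3-methylphenoxy group or the piperazine linker of the shared core would do so.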